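Dichloro anilines on two cores: a second chloro step

This account rests on a few compounds, and the source may have more. Where it says the series, first, only, none or still open, it means among the compounds named here.

Compound 2 `Clc1cccc(Nc2ccc(N3CC4CC(C3)N4)cn2)c1` gives 2.2 nM in an assay on cell membranes for displacement of a labelled ligand from Neuronal acetylcholine receptor; alpha4/beta2 (Rattus norvegicus) (on this read-out lower numbers stand for stronger inhibition and higher numbers for weaker inhibition), the lowest of the three measured values. Compound 3 `Clc1ccc(Nc2ccc(N3CC4CC(C3)N4)nn2)cc1` gives 90.4 nM in this assay, and compound 1 `Clc1ccc(Nc2ccc(N3CC4CC(C3)N4)nn2)cc1Cl` gives 516 nM in this assay. Compound 2 and compound 3 differ in their cores; the difference between the two cores is not broken down here. On the core of compound 3, the change to compound 1 is chloro in place of hydrogen on an aromatic carbon, and it made a 5.7-fold higher number from compound 3 to compound 1 (0.76 log units; beyond the scatter). Compound 4 `Clc1ccc(Nc2ccc(N3CC4CC(C3)N4)cn2)cc1Cl` is the unmeasured analogue of compound 2 carrying the same kind of change, (chloro in place of hydrogen on an aromatic carbon). The two places are not identical: in the step to compound 1 the entering chloro sits meta to a large group, whereas in compound 4 it sits para to a large group. For the measured compounds named here, only one example of this kind of change is measured. Going by the values given here, for the move to compound 4 a step in the same direction is expected, a 3.6-fold higher number from compound 2 to compound 4 (0.56 log units; beyond the scatter), resting on a 5.7-fold higher number from compound 3 to compound 1 (0.76 log units; beyond the scatter) in this assay as the sole precedent. Compound 4 is expected to give 8 nM in this assay, between 2 nM and 30 nM.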

Compound 4, inhibition constant: 2.3 nM
Beside the measured number, compound 4's estimate is 3.5-fold (0.54 log units) above it, within the range that was stated.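

In this assay chloro in place of hydrogen gives a 1.0-fold higher number from compound 2 to compound 4 (0.02 log units; within the scatter), so on the core of compound 2 this change leaves the number level. For the compounds shown here, each core contributes only one pair, and the entering chloro does not stand in the same place in the two pairs, so these data cannot separate the effect of the core from the effect of the place and give no cause for the gap. What they do show is that the size of this step cannot be assumed to carry from one core to the other in this series: the same change on two cores in this assay, a 5.7-fold higher number (0.76 log units; beyond the scatter) from compound 3 to compound 1 and a 1.0-fold higher number (0.02 log units; within the scatter) from compound 2 to compound 4, 5.5-fold (0.74 log units) apart, beyond the scatter of two such steps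

The compounds shown leave open whether the level result on the core of compound 2 is particular to chloro or also holds for a fluoro, methyl or methoxy group at the same place. They also leave open how an analogue of compound 2 carrying hydrogen in place of its existing chloro would compare.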